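The source may report more compounds than this note shows. Statements on the series, on what has been measured and on what is new or still open speak of the compounds shown alone.

Compound 1, `COc1cc(C2CC(c3ccco3)=NN2C(C)=O)cc(OC)c1OC`, and compound 2, `COc1ccc(C2CC(c3ccco3)=NN2C(C)=O)cc1OC`, share a core and differ in one place. In a functional assay on OVCAR cells (Homo sapiens) for cytotoxicity, read by sulforhodamine B assay, with a stated time of 48 h (on this read-out lower numbers stand for stronger inhibition and higher numbers for weaker inhibition), compound 1 gives 10900 nM. Compound 2, in this assay, gives 31200 nM. The change between them, (hydrogen in place of methoxy on an aromatic carbon), produced a 2.9-fold higher number from compound 1 to compound 2 (0.46 log units; beyond the scatter).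

Compound 3, `COc1ccc(C2CC(c3ccc4ccccc4c3)=NN2CC=O)c(OC)c1OC`, has a different core; the difference between the two cores is not broken down here. In this assay compound 3 gives 580 nM, the lowest of the three numbers, with compound 1 and compound 2 both giving higher numbers beyond the usual scatter.

Compound 4, `COc1ccc(C2CC(c3ccc4ccccc4c3)=NN2CC=O)cc1OC`, is not yet measured. It stands to compound 3 as compound 2 stands to compound 1: the change is hydrogen in place of methoxy on an aromatic carbon. It is the same kind of change as that from compound 1 to compound 2, not the same, since here the carbon that loses the methoxy is ortho to a large group and ortho to a methoxy group, whereas in the earlier pair it was ortho to a methoxy group and meta to the large group.

Among the measured compounds shown here, the expectation for compound 4 in this assay rests on the one earlier step of this kind, a 2.9-fold higher number from compound 1 to compound 2 (0.46 log units; beyond the scatter), and on compound 3 at 580 nM, so a step of about a 2.9-fold higher number from compound 3 to compound 4 (0.47 log units; beyond the scatter) is estimated. Compound 4 is therefore expected to give 1700 nM, with a likely range of 700 nM to 4500 nM.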

Compound 4, half-maximal inhibitory concentration: 2450 nM
Compound 4: the middle estimate sits 1.4-fold (0.16 log units) below what was measured; the measured number falls inside the stated range.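

On the second core the change behaves as it did on the first: in this assay, hydrogen in place of methoxy on an aromatic carbon gives a 4.2-fold higher number from compound 3 to compound 4 (0.63 log units; beyond the scatter), so the number rises in both pairs, and by a modest amount in both. Set side by side, the two steps cannot be told apart in size: the same change on two cores in this assay, a 2.9-fold higher number (0.46 log units; beyond the scatter) from compound 1 to compound 2 and a 4.2-fold higher number (0.63 log units; beyond the scatter) from compound 3 to compound 4, 1.5-fold (0.17 log units) apart, within the scatter of two such steps This shows that, for these two cores, the loss of this methoxy can be carried from one to the other as a step of similar direction and size, but it rests on only two pairs in a single cell assay, so it does not establish a rule for other cores or other cells, and it does not explain why the step occurs.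

The compounds shown hold only methoxy or hydrogen at this carbon, which leaves open how a hydroxyl group, a fluorine atom, an amine or a longer ethoxy chain would behave there. They also leave open which of the differences between the two cores goes with the lower numbers of compound 3 and compound 4.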